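Chloro to bromo on a boronic acid chalcone

The source may hold more compounds than are shown below. What is called first, only, known or untested is meant among the compounds shown, and "the series" means these compounds.

Among the measured compounds shown here, in a functional assay on MCF7 cells (Homo sapiens) for inhibition (on this read-out higher numbers stand for weaker inhibition and lower numbers for stronger inhibition), compound 2 `O=C(/C=C/c1ccc(F)c(Cl)c1)c1ccc(B(O)O)cc1` gives 6000 nM, the lower of the two numbers measured so far; compound 1 `O=C(/C=C/c1ccc(B(O)O)cc1)c1ccc[nH]1` gives 19000 nM, a gap that lies beyond the usual scatter. Compound 3 `O=C(/C=C/c1ccc(F)c(Br)c1)c1ccc(B(O)O)cc1` differs from compound 2 by a single exchange: bromo in place of chloro on an aromatic carbon. For the measured compounds named here, no step of this kind has been measured here, so the expected step from compound 2 to compound 3 in this assay is a 1.2-fold lower number from compound 2 to compound 3 (0.08 log units; within the scatter), not beyond the scatter. Compound 3 is therefore estimated at 5000 nM, within a range of 2500 nM to 12000 nM.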

Compound 3, half-maximal inhibitory concentration: 8500 nM
Beside the measured number, compound 3's estimate is 1.7-fold (0.23 log units) below it; the measured number falls inside the stated range.
By their numbers in this assay, from the lowest: compounds 2 and 3 (each within the scatter of the next); then compound 1.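

In this assay, bromo in place of chloro, on an aromatic carbon ortho to a fluoro group and meta to a large group, gives a 1.4-fold higher number from compound 2 to compound 3 (0.15 log units; within the scatter). The earlier compounds shown here gave no reading at this position; now it is seen to take either chloro or bromo, with compound 2 and compound 3 within the scatter of each other. Nothing at hand bears on a cause for this result. As far as these compounds go, it remains open whether an amine or a methoxy group at this position would shift the number beyond the scatter. From the compounds shown here alone, whether a carboxylic acid could stand in place of the boronic acid also remains open.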